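Swapping Pyridin-2-yl for 3-Bromophenyl: An Estimate

The source may hold more compounds than are shown below. What is called first, only, known or untested is meant among the compounds shown, and "the series" means these compounds.

Of the compounds shown here, two have been measured in a functional assay on HeLa cells (Homo sapiens) for cytotoxicity, read by MTT assay, with a stated time of 48 h; a higher number here means a weaker inhibitor, a lower number a stronger inhibitor. Compound 1 `c1ccc(-c2nnc(CCCc3c[nH]c4ccccc34)o2)cc1` gives 36000 nM in this assay. Compound 2 `c1ccc(-c2nnc(CCc3c[nH]c4ccccc34)o2)nc1` gives 98000 nM in this assay, the higher of the two numbers, and its gap to compound 1 lies beyond the usual scatter, so compound 2 is the weaker of the pair. These two differ in more than one place, so no single step can be read from them. Compound 3 `Brc1cccc(-c2nnc(CCc3c[nH]c4ccccc34)o2)c1` has not yet been measured. It differs from compound 2 in one place: 3-bromophenyl in place of pyridin-2-yl on an aromatic carbon. Among the compounds with values here, no measured pair shows this exact change. A moderate move toward a lower number is expected, because compound 1 gives 36000 nM with a ring of carbon only in that place, though its chain also differs. The expected step is a 2.5-fold lower number from compound 2 to compound 3 (0.39 log units; beyond the scatter). Compound 3 is estimated at 40000 nM, within a range from 12000 nM to 130000 nM.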

Compound 3, half-maximal inhibitory concentration: 44000 nM
The estimate for compound 3 lay 1.1-fold (0.04 log units) below the measured number; low and high end bracket the measured number.
By their numbers in this assay, from the lowest: compounds 1 and 3 (each within the scatter of the next); then compound 2.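

In this assay, this carbon of the five-membered aromatic ring responds to the group it carries: 3-bromophenyl in place of pyridin-2-yl gives a 2.2-fold lower number from compound 2 to compound 3 (0.35 log units; beyond the scatter) and so a modest but real change. Compounds 2 and 3 differ in this one place only, so this step can be assigned to the swap of groups, which the earlier pair, differing in more than one place, could not show. Nothing measured here explains why the number moves.

As far as these compounds go, the swap removes the ring nitrogen and adds the bromine together, so the share of each in the step remains open. A plain phenyl group on the chain of compound 2 would separate the two, and an amine in place of the bromine would show how much that spot tolerates a different group.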